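This account rests on a few compounds, and the source may have more. Where it says the series, first, only, none or still open, it means among the compounds named here.

Compound 1 `Nc1nc(N/N=C/c2cncs2)nc2c1ncn2[C@@H]1O[C@H](CO)[C@@H](O)[C@H]1O` gives the lowest number in an assay on CHO-K1 cells for displacement of a labelled ligand from adenosine receptor A1 (Homo sapiens), read by scintillation counting, with a stated time of 60 min (a lower number here means a stronger inhibitor, a higher number a weaker inhibitor), where compound 1 gives 22 nM. Compound 3 `COc1cc(/C=N/Nc2nc(N)c3ncn([C@@H]4O[C@H](CO)[C@@H](O)[C@H]4O)c3n2)ccc1OCc1ccccc1` sits far from it, giving 9140 nM in this assay. Compound 2 `Nc1nc(N/N=C/c2ccc(C(F)(F)F)cc2C(F)(F)F)nc2c1ncn2[C@@H]1O[C@H](CO)[C@@H](O)[C@H]1O` returns only a limit of this assay, namely > 10000 nM; the assay stops at the limit of > 10000 nM in this assay, at which 1 of the 3 values shown sits. Compound 4 `N#Cc1ccc(/C=N/Nc2nc(N)c3ncn([C@@H]4O[C@H](CO)[C@@H](O)[C@H]4O)c3n2)cc1` has not yet been measured, and it differs from compound 1 in a single place (4-cyanophenyl in place of 1,3-thiazol-5-yl on a carbon with a double bond to nitrogen). Within the data shown here, no pair of measured compounds isolates this replacement. Since compound 3 gives 9140 nM, a six-membered carbon ring in this position is expected to cost a large amount of binding. Compound 4 is therefore expected at 900 nM, within 150 nM to 6000 nM, a loss a 41-fold higher number from compound 1 to compound 4 (1.61 log units; beyond the scatter) expected to lie well beyond the scatter.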

Compound 4, inhibition constant: 4.1 nM
Compound 4: middle estimate off by 220-fold (2.34 log units), on the high side, and the stated range ends above it.
By their numbers in this assay, from the lowest: compound 4; then compound 1; then compound 3. At a limit, above all of these: compound 2.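

In this assay, replacing the thiazole gives a 5.4-fold lower number from compound 1 to compound 4 (0.73 log units; beyond the scatter). The 1,3-thiazol-5-yl group is therefore not required for a low number at this position, on a carbon with a double bond to nitrogen. A six-membered aromatic ring of carbon only, carrying a nitrile, can take its place and still give a low number.

The data shown give no reason for this gain. On these data alone, it remains open whether a carboxylic acid or an amine in place of the nitrile would keep such a low number.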